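From Alkenyl Sulfide to Fluorobenzyl Sulfide at Toll-like Receptor 2

The compounds below may be only part of what the source reports. "The series", "measured", "known", "first", "only" and "open" are said of these compounds alone.

Compound 3 `C=CCCSC[C@H](NC(=O)c1cc(OC)c(OC)c(OC)c1)C(=O)OC` gives 27300 nM in an assay on RAW264.7 cells for antagonist activity at Toll-like receptor 2 (Mus musculus), read by Griess assay, with a stated time of 24 h (a higher number here means a weaker inhibitor, a lower number a stronger inhibitor), the lowest of the three numbers shown, though not separated from its nearest neighbour beyond the scatter. Compound 1 `C=CCCCSC[C@H](N)C(=O)OC` gives 31300 nM in this assay, within the scatter of compound 3, while compound 2 `C#CCSC[C@H](N)C(=O)OC` gives 94400 nM. Going by the values given here, the one single-site step measured, a 3.0-fold higher number from compound 1 to compound 2 (0.48 log units; beyond the scatter), also sits on a saturated chain carbon bound to a sulfur. Compound 4 `COC(=O)[C@H](CSCc1ccc(F)cc1)NC(=O)c1cc(OC)c(OC)c(OC)c1` differs from compound 3 by 4-fluorophenyl in place of allyl on a saturated chain carbon bound to a sulfur. Among the compounds with values here, no measured step matches this change, and the measured step concerns a different group, so only a modest movement in either direction is expected. For compound 4 the expected value is 20000 nM, with a range from 6000 nM to 70000 nM. This corresponds to an expected step of a 1.4-fold lower number from compound 3 to compound 4 (0.14 log units; within the scatter).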

Compound 4, half-maximal inhibitory concentration: 28600 nM
For compound 4 the middle estimate is 1.4-fold (0.16 log units) below the measured one; measured number inside the range.
By their numbers in this assay, from the lowest: compounds 3, 4 and 1 (each within the scatter of the next); then compound 2.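

Going by these compounds alone, at this place, on a saturated chain carbon bound to a sulfur, the earlier compounds carried only open chains. Compound 4 shows that a 4-fluorophenyl, with its six-membered aromatic ring, can replace allyl in this assay without separating the two numbers: the step is a 1.0-fold higher number from compound 3 to compound 4 (0.02 log units; within the scatter). No measurement shown accounts for this result.

As far as these compounds go, the ring and the fluorine enter together, so their separate contributions remain open. From the compounds shown here alone, whether a plain benzyl, a 4-chlorobenzyl or a chain ending in an amine would read alike at this place also stays open.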